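Swapping One Aromatic Group on Compound 3 for 4-Fluorophenyl

A few compounds are considered here, and "the series" means these few. Any claim that something is new, unique, unknown or untested is made for them only; others in the source may bear on it.

Three related compounds have numbers in a functional assay for inhibition, with Homo sapiens as the target; on this read-out lower numbers stand for tighter binding and higher numbers for weaker binding. Compound 1 `O=C(O)CC/C=C\CC1COC(c2cccnc2)OC1c1cccnc1` gives 759 nM and compound 2 `O=C(O)CC/C=C\CC1COC(c2ccco2)OC1c1cccnc1` gives 1260 nM on this scale. Compound 3 `CSc1ccc(OC(C)(C)C2OCC(C/C=C\CCC(=O)O)C(c3cccnc3)O2)c([N+](=O)[O-])c1` gives 4.47 nM, the lowest of the three numbers and beyond the scatter from both others.

Compound 4 `CC(C)(Oc1ccc(F)cc1)C1OCC(C/C=C\CCC(=O)O)C(c2cccnc2)O1` has not been measured. It differs from compound 3 in one group: a group of 7 heavy atoms (6 carbon, 1 fluorine; one six-membered aromatic ring of carbon only) in place of a group of 11 heavy atoms (7 carbon, 1 nitrogen, 2 oxygen, 1 sulfur; one six-membered aromatic ring of carbon only), on an oxygen on a saturated carbon.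

Within the data shown here, only one measured step compares two compounds that differ in one place: a 1.7-fold higher number from compound 1 to compound 2 (0.22 log units; within the scatter). That swap lies elsewhere in the molecule and stays within the scatter, so it offers little guidance here. A weaker clue comes from the values themselves. Compound 4 keeps a six-membered aromatic ring of carbon only on that oxygen, as does compound 3 with 4.47 nM, whereas compound 1 with 759 nM has no such group there. Among the measured compounds shown here, compound 4 is therefore expected to stay much nearer to compound 3 than to compound 1, yet no measured compound shows what this particular swap does. A moderate move towards weaker binding is expected, and the estimated change is a 4.5-fold higher number from compound 3 to compound 4 (0.65 log units; beyond the scatter). For compound 4 the estimated value is 20 nM in this assay, with an expected range of 4 nM to 100 nM.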

Compound 4, dissociation constant: 120 nM
The estimate for compound 4 lay 6.0-fold (0.78 log units) below the measured number, outside the stated range (above it).
By their numbers in this assay, from the lowest: compound 3; then compound 4; then compounds 1 and 2 (each within the scatter of the next).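

The earlier step, a swap on a saturated ring carbon, stayed within the scatter, but this change, made on an oxygen on a saturated carbon, shows that the molecule can respond strongly to what is attached there: in this assay it gives a 27-fold higher number from compound 3 to compound 4 (1.43 log units; beyond the scatter). Both groups carry a six-membered aromatic ring of carbon only, so having such a ring in this place is not enough by itself to preserve the low number of compound 3, 4.47 nM. No measurement shown here explains the size of this step.

The swap removes the nitrogen, both oxygens and the sulfur of the departing group and brings in a fluorine, all in one change, so these compounds cannot separate the contribution of each atom or of the parts that contain them. Going by these compounds, it remains open how an unsubstituted phenyl, or a phenyl carrying a methoxy group or a nitrile, would compare with compound 3 and compound 4 when placed on the same oxygen.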